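Notes on compound 2 and the untested compound 3

The source may hold more compounds than are shown below. What is called first, only, known or untested is meant among the compounds shown, and "the series" means these compounds.

Of the compounds shown here, two of the shared core have been measured in an assay for inhibition of inositol hexakisphosphate kinase 3 (Homo sapiens), read by colorimetric assay, coupled enzyme assay and malachite green, with a stated time of 120 min, in the presence of a further agent that is not named here; on this read-out lower numbers stand for stronger inhibition and higher numbers for weaker inhibition. Compound 1 `CNC(=O)/C=C/c1ccc2noc(-c3ccccc3)c2c1` gives 42600 nM. Compound 2 `O=C(O)c1ccc2noc(-c3ccc(Oc4ccccc4)cc3)c2c1` gives 550 nM, the lowest of the two numbers; its gap to compound 1 is far beyond the usual scatter. Going by the values given here, the two measured compounds differ in more than one place, so no single-point step between measured compounds is available as a guide.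

Compound 3 `O=C(O)c1ccc2noc(-c3ccc(NC(=O)c4ccncn4)cc3)c2c1` differs from compound 2 in one place: ((pyrimidin-4-yl)carbonyl)amino in place of phenoxy on an aromatic carbon. The carboxylic acid of compound 2 is kept, and the exchange sits on an aromatic carbon of a six-membered aromatic ring of carbon only, para to a large group.

Among the compounds with values here, with no measured step of this kind, the expectation rests on compound 2 alone. A modest step toward a weaker number is expected, though a step within the scatter cannot be excluded; the expected step is a 1.6-fold higher number from compound 2 to compound 3 (0.21 log units; within the scatter). Compound 3 is therefore estimated at 900 nM in this assay, with a likely range from 150 nM to 5000 nM.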

Compound 3, half-maximal inhibitory concentration: 430 nM
For compound 3 the middle estimate is 2.1-fold (0.32 log units) above the measured one; low and high end bracket the measured number.
By their numbers in this assay, from the lowest: compounds 3 and 2 (each within the scatter of the next); then compound 1.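

In this assay the aromatic carbon para to a large group takes ((pyrimidin-4-yl)carbonyl)amino in place of phenoxy with a 1.3-fold lower number from compound 2 to compound 3 (0.11 log units; within the scatter) and the two groups are not told apart on this read-out. The carboxylic acid stays in place while the six-membered aromatic ring of carbon only in phenoxy gives way to a six-membered aromatic ring with 2 hetero atoms, and the substituent goes from 0 hydrogen-bond donors and 1 hydrogen-bond acceptor to 1 hydrogen-bond donor and 3 hydrogen-bond acceptors, so this position accepts two quite different groups without a readable change in the number. Nothing at hand speaks to why the number holds across so large an exchange.

As far as these compounds go, whether the ring nitrogens of the entering group count for anything remains open, and (phenylcarbonyl)amino or a plain amine on the same aromatic carbon would test this. Also open, from the compounds shown here alone, is what the carboxylic acid itself contributes, since a methyl ester or a primary amide in its place would be needed to read that single change on the shared core.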